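This account rests on a few compounds, and the source may have more. Where it says the series, first, only, none or still open, it means among the compounds named here.

Compound 1 `COc1ccc(C2CC2C(=O)NNc2nncc3ccccc23)cc1` and compound 2 `CC(C)=CCOc1ccc(C2CC2C(=O)NNc2nncc3ccccc23)cc1` share one core and differ only in one spot: 2-methylprop-1-en-1-yl in place of hydrogen on a saturated chain carbon bound to an oxygen on an aromatic ring In a functional assay on U-373MG ATCC cells (Homo sapiens) for inhibition, read by MTT assay, with a stated time of 72 h (on this read-out higher numbers stand for weaker inhibition and lower numbers for stronger inhibition), compound 1 gives 83000 nM, and compound 2 gives 81000 nM. The step of a 1.0-fold lower number from compound 1 to compound 2 (0.01 log units; within the scatter) shows that this change left the read-out essentially where it was.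

Compound 3 `COc1ccc(C2CC2C(=O)NNC(=O)c2ccncc2)cc1` carries a different core, and the difference between the two cores is not broken down here. In this assay compound 3 reaches only the assay limit, > 100000 nM, because the limit of > 100000 nM in this assay, at which 1 of the 3 values shown sits, marks where its value sits rather than a measured number.

Compound 4 `CC(C)=CCOc1ccc(C2CC2C(=O)NNC(=O)c2ccncc2)cc1` is not yet measured. It stands to compound 3 exactly as compound 2 stands to compound 1: 2-methylprop-1-en-1-yl in place of hydrogen on a saturated chain carbon bound to an oxygen on an aromatic ring The place is described in the same words for both pairs, so this is the same change made on a second core.

For compound 4 in this assay the step that the limit leaves unreadable from compound 3 to compound 4 is expected to be as flat as the earlier one, an expectation resting on compound 1 and compound 2, whose step a 1.0-fold lower number from compound 1 to compound 2 (0.01 log units; within the scatter) fell within the usual scatter. With compound 3 already at the assay limit, compound 4 is estimated at 150000 nM, with a range from 60000 nM to 400000 nM, and most likely it too will be reported only as a limit.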

Compound 4, half-maximal inhibitory concentration: > 100000 nM
Compound 4: no number, only a limit; the forecaster's own chance of this, stated with the estimate: 75%; the middle value does not contradict the limit.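

In this assay, compound 3 and compound 4 are both reported only as limits, not as numbers, so no step between them can be read: the limit of > 100000 nM in this assay, at which 2 of the 4 values shown sit.

The compounds shown leave open how far the change from methoxy to (3-methylbut-2-en-1-yl)oxy moves the read-out on the core of compound 3, and whether it makes as little difference there as on the core of compound 1.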